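Phenyl for dimethylphenyl on the piperazine nitrogen

The compounds below may be only part of what the source reports. "The series", "measured", "known", "first", "only" and "open" are said of these compounds alone.

Measured compounds:
compound 1, `CCc1nc(-c2ccc(C(C)(C)C)cc2)c(C(=O)N2CCN(c3cccc(OC)c3)CC2)o1`, "not active" (no number reported)
compound 2, `Cc1ccc(N2CCN(C(=O)c3oc(C)nc3-c3ccccc3)CC2)c(C)c1`, 101 nM
compound 3, `COc1cc(OC)cc(N2CCN(C(=O)c3oc(C)nc3-c3cccc(F)c3)CC2)c1`, 28.2 nM

Of the compounds shown here, three sharing the same core have been tested in a functional assay on HL-60 cells (Homo sapiens) for inhibition, read by MTT assay, with a stated time of 72 h; a higher number here means a weaker inhibitor, a lower number a stronger inhibitor. Compound 1 is recorded as "not active" (no number reported), so no number is attached to it. Of the two compounds with a number, compound 2 gives 101 nM in this assay, which is the higher of the two, and compound 3 gives 28.2 nM, a lower number by a margin that is beyond the scatter. Compound 2 therefore stands as the weaker of the two numbered compounds.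

Compound 4, `Cc1nc(-c2ccccc2)c(C(=O)N2CCN(c3ccccc3)CC2)o1`, has not yet been measured. It differs from compound 2 in one place: phenyl in place of 2,4-dimethylphenyl on an amine nitrogen in a ring. Among the compounds with values here, no pair of measured compounds isolates this change, and compound 3 differs from both in two places, so the comparison offers only a rough guide. The change removes two methyl groups and leaves the rest of the molecule unchanged. He expects a step from compound 2 to compound 4 of a 1.6-fold higher number from compound 2 to compound 4 (0.20 log units; within the scatter) in this assay, in the direction of a somewhat weaker compound but not with confidence that it lies beyond the scatter. His estimate for compound 4 in this assay is 160 nM, with a range from 50 nM to 600 nM.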

Compound 4, half-maximal inhibitory concentration: 39.1 nM
For compound 4 the middle estimate is 4.1-fold (0.61 log units) above the measured one; the whole stated range lies above it.
By their numbers in this assay, from the lowest: compounds 3 and 4 (each within the scatter of the next); then compound 2.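

In this assay the exchange of 2,4-dimethylphenyl for phenyl on an amine nitrogen in a ring gives a 2.6-fold lower number from compound 2 to compound 4 (0.41 log units; beyond the scatter) and is the only single change that can be read among these compounds. It shows that the two methyl groups are not needed for activity at this position: in this one pair, the unsubstituted phenyl goes with the stronger inhibitor, although the step is modest. No evidence is available on what lies behind this step.

What this leaves open is whether the step comes from one methyl group or needs both, and whether a single methyl group, a chlorine atom or a pyridine ring on this nitrogen would match or better the plain phenyl. Compound 1 and compound 3 each differ from compound 4 in more than one place, so they cannot tell whether the same exchange would give a similar step with the other groups that they carry on the shared core.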